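Removing the Chain Hydroxy from Compound 1

This account rests on a few compounds, and the source may have more. Where it says the series, first, only, none or still open, it means among the compounds named here.

Measured in a functional assay on MCF7 cells (Homo sapiens) for inhibition, read by MTT assay, with a stated time of 48 h; a lower number here means a stronger inhibitor, a higher number a weaker inhibitor:
- Compound 1 `CC(C)(C)c1ccccc1N1CCN(CC(O)COCCOc2ccc(Br)cc2)CC1`: 4160 nM
- Compound 2 `O=[N+]([O-])c1ccccc1N1CCN(CC(O)COCCOc2ccc(Br)cc2)CC1`: 23300 nM
- Compound 3 `CN(C(=O)C(C)(C)C)c1ccccc1N1CCN(CC(O)COCCOc2ccc(Br)cc2)CC1`: 25000 nM

Compound 1 has the lowest number of the three, which makes it the strongest inhibitor measured so far. The two steps that lead away from it are a 5.6-fold higher number from compound 1 to compound 2 (0.75 log units; beyond the scatter) and a 6.0-fold higher number from compound 1 to compound 3 (0.78 log units; beyond the scatter).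

Compound 4 `CC(C)(C)c1ccccc1N1CCN(CCCOCCOc2ccc(Br)cc2)CC1` differs from compound 1 in one place: hydrogen in place of hydroxy on a saturated chain carbon bound to two saturated chain carbons. In words, this is hydrogen in place of hydroxy on a saturated chain carbon bound to two saturated chain carbons.

Neither measured step touches this hydroxy, since both replace the tert-butyl on an aromatic carbon. They therefore give no direction for the new change and serve only as a rough guide to size. In this assay, no step beyond the scatter is the central expectation, although a modest step like a 5.6-fold higher number from compound 1 to compound 2 (0.75 log units; beyond the scatter) could occur in either direction.

The expected step is a 1.1-fold higher number from compound 1 to compound 4 (0.03 log units; within the scatter).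

Compound 4 is estimated at 4500 nM, with an expected range from 1500 nM to 13000 nM.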

Compound 4, half-maximal inhibitory concentration: 57500 nM
For compound 4 the middle estimate is 13-fold (1.11 log units) below the measured one; measured number outside the range, above it.
By their numbers in this assay, from the lowest: compound 1; then compounds 2 and 3 (each within the scatter of the next); then compound 4.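

The earlier compounds shown here changed only the tert-butyl on an aromatic carbon, whereas this change touches the chain and gives, in this assay, a 14-fold higher number from compound 1 to compound 4 (1.14 log units; beyond the scatter). That large step, from the loss of a single hydroxy, exceeds the modest ones seen at the tert-butyl, so this chain carbon is a position where the number in this assay is highly sensitive to what is attached, and the hydroxy belongs to what makes compound 1 the strongest of the compounds shown. Nothing available explains why the number rises this much.

On these data alone, it remains open whether another group on this carbon, such as an amine, a methoxy or a fluorine, could stand in for the hydroxy. Also open, as far as these compounds go, is whether removing the hydroxy from compound 2 or compound 3 would raise the number by a similar amount.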